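The compounds below may be only part of what the source reports. "The series", "measured", "known", "first", "only" and "open" are said of these compounds alone.

The account concerns agonist activity at the cold-sensing channel, measured in an assay on HEK293 cells for agonist activity at transient receptor potential cation channel subfamily M member 8 (Homo sapiens), read by fluorescence and calcium flux, with a stated time of 15 min; a lower number here means that less compound is needed, a higher number that more compound is needed for the effect. Compound 1, with the structure `Cc1ccc(OCC(=O)N(Cc2cccs2)c2ccccn2)cc1`, gives 200 nM in this assay and thereby stands lowest of the two numbers recorded. Its nearest neighbour, compound 2, drawn as `CCN(Cc1cccs1)C(=O)C(C)Oc1ccc(C)cc1`, gives 889 nM in this assay, a gap that lies beyond the usual scatter. Among the compounds with values here, the two compounds differ in more than one place, so no single step between them is set out; their values alone are known.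

The step followed here leads from compound 1 to compound 3, whose structure is `Cc1ccc(OCC(=O)N(O)Cc2cccs2)cc1`. The change is hydroxy in place of pyridin-2-yl on an amide-type nitrogen. Within the data shown here, the data hold no measured step for a change of this kind, so the expectation rests on the structural change alone. The step from compound 1 to compound 3 is expected to raise the number, a 13-fold higher number from compound 1 to compound 3 (1.10 log units; beyond the scatter), beyond the scatter. Compound 3 is accordingly estimated at 2500 nM, within a range from 500 nM to 12000 nM.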

Compound 3, half-maximal effective concentration: 8000 nM
Compound 3: middle estimate off by 3.2-fold (0.51 log units), on the low side; low and high end bracket the measured number.
By their numbers in this assay, from the lowest: compound 1; then compound 2; then compound 3.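

On the amide-type nitrogen whose other neighbours are a carbonyl carbon and a saturated chain carbon, hydroxy in place of pyridin-2-yl gives a 40-fold higher number from compound 1 to compound 3 (1.60 log units; beyond the scatter) in this assay and so marks a large step. Within the data shown here, compounds 1 and 2 differ in more than one place, so this is the first single change at this nitrogen, and it shows that the number at this position is far from indifferent to exchanging a six-membered aromatic ring for a single oxygen-bearing group. No measurement at hand says why the number rises.

A single step cannot separate the departure of the ring from the arrival of the hydroxy. On these data alone, whether a phenyl ring, a pyridin-3-yl or a methoxy on this nitrogen would keep the number near that of compound 1, which gives 200 nM, remains open.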